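Homologating the Ester Chain on a Weak Amine Oxidase B Inhibitor

This account rests on a few compounds, and the source may have more. Where it says the series, first, only, none or still open, it means among the compounds named here.

Compound 1, `COC(=O)CN1C(=O)c2ccccc2NC1c1ccccc1`: 720000 nM
Compound 2, `COC(=O)CN1C(=O)c2ccccc2NC1c1ccc(OC)cc1`: 560000 nM

Of the compounds shown here, two sharing one core have been tested in an assay on mitochondria for inhibition of Amine oxidase [flavin-containing] B (Bos taurus), read by fluorescence, with a stated time of 60 min; a higher number here means a weaker inhibitor, a lower number a stronger inhibitor. In this assay compound 1 gives 720000 nM, the highest of the two numbers, and compound 2 gives 560000 nM. Among the measured compounds shown here, the only step between them, a 1.3-fold lower number from compound 1 to compound 2 (0.11 log units; within the scatter), is within the scatter, so nothing about order can be drawn from it.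

Compound 3, `COC(=O)CCN1C(=O)c2ccccc2NC1c1ccccc1`, is not yet measured. It differs from compound 1 in that ((methoxycarbonyl)methyl in place of methoxycarbonyl on a saturated chain carbon bound to an amide-type nitrogen in a ring). For the measured compounds named here, no measured step touches this chain; the one step in hand concerns an aromatic substituent and is within the scatter, so it offers no direction. Compound 3 is therefore expected to stay close to compound 1, with a 1.0-fold lower number from compound 1 to compound 3 (0.01 log units; within the scatter) expected to lie within the scatter. The estimate for compound 3 is 700000 nM, with a range from 300000 nM to 1600000 nM.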

Compound 3, half-maximal inhibitory concentration: 860000 nM
Compound 3: middle estimate off by 1.2-fold (0.09 log units), on the low side; the measured number falls inside the stated range.
By their numbers in this assay, from the lowest: compounds 2, 1 and 3 (each within the scatter of the next).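

Compound 3 gives this chain its own measured step: going from (methoxycarbonyl)methyl to 2-(methoxycarbonyl)ethyl on the amide-type nitrogen in a ring gives a 1.2-fold higher number from compound 1 to compound 3 (0.08 log units; within the scatter) in this assay. At this position, then, the added chain carbon leaves the two compounds indistinguishable, and both numbers remain in the same high range. The earlier step concerned only an aromatic methoxy group, so it said nothing about this chain. No outside data bear on this result.

Going by these compounds, it remains open whether a longer chain, a carboxylic acid in place of the methyl ester, or an amine at the end of the chain would move the number beyond the scatter. Also open, on these data alone, is whether any change on this chain could give a clearly stronger inhibitor than compound 1.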